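The source may hold more compounds than are shown below. What is called first, only, known or untested is meant among the compounds shown, and "the series" means these compounds.

Compound 3 `Cc1c(O)ccc2c1[C@H](Cn1cc(-c3ccc(C(F)(F)F)cc3)nn1)[C@@]13CC(=O)[C@@](C)(CC[C@@H]21)C3` carries a 4-(trifluoromethyl)phenyl group on the shared core. In a functional assay on SW480 cells (Homo sapiens) for cytotoxicity, read by MTT assay, with a stated time of 4 days (a lower number here means a stronger inhibitor, a higher number a weaker inhibitor), compound 3 gives > 20000 nM, which is a limit of the assay rather than a measured number. Its two neighbours stand no differently. Compound 1 `Cc1c(O)ccc2c1[C@H](Cn1cc(-c3ccccc3)nn1)[C@@]13CC(=O)[C@@](C)(CC[C@@H]21)C3` carries a plain phenyl in that position; in this assay compound 1 gives > 20000 nM, again a limit. Compound 2 `Cc1c(O)ccc2c1[C@H](Cn1cc(-c3ccccn3)nn1)[C@@]13CC(=O)[C@@](C)(CC[C@@H]21)C3` carries a pyridin-2-yl; in this assay compound 2 gives > 20000 nM, also a limit. All three values thus sit at the same limit (the limit of > 20000 nM in this assay, at which 3 of the 3 values shown sit), and the steps between them, a step that the two limits leave unreadable from compound 1 to compound 2, a step that the two limits leave unreadable from compound 1 to compound 3 and a step that the two limits leave unreadable from compound 2 to compound 3, cannot be sized.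

Compound 4 `COc1ccc(-c2cn(C[C@H]3c4c(ccc(O)c4C)[C@@H]4CC[C@@]5(C)C[C@]43CC5=O)nn2)cc1` is the next member of the set. The change from compound 3 is methoxy in place of trifluoromethyl on an aromatic carbon. Each of the three measured steps bears on this change only in a weak way: replacing one aromatic substituent by another has so far always left the value at the limit, and none of the steps gives a readable size or direction. Compound 4 is therefore expected to remain at the same limit, with the step that the limit leaves unreadable from compound 3 to compound 4 expected to be nothing beyond the scatter. The estimate for compound 4 in this assay is 25000 nM, within a range from 8000 nM to 80000 nM.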

Compound 4, half-maximal inhibitory concentration: > 20000 nM
Compound 4: no number, only a limit; the forecaster's own chance of this, stated with the estimate: 80%; the middle value lies beyond the limit too.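

In this assay compound 4 gives > 20000 nM, which is a limit and not a measured number. The steps joining compound 1, compound 2 and compound 3 to compound 4 therefore cannot be read: the limit of > 20000 nM in this assay, at which 4 of the 4 values shown sit.

The compounds shown leave open how far apart these four truly stand, and what change to the shared core would give a measured number in this assay.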